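Difluorophenyl in place of methoxyphenyl on the carbonyl carbon

A few compounds are considered here, and "the series" means these few. Any claim that something is new, unique, unknown or untested is made for them only; others in the source may bear on it.

Of the compounds shown here, three sharing one core have been measured in a functional assay on BT-549 cells (Homo sapiens) for cytotoxicity, read by sulforhodamine B assay, with a stated time of 48 h, tested at 100 uM; on this read-out higher numbers stand for a weaker effect at the one concentration tested and lower numbers for a stronger effect. Compound 1 `COc1cc(-c2cc(/C=C/C(=O)c3ccc(N)cc3)[nH]n2)cc(OC)c1OC` gives -97%. Compound 2 `COc1cc(-c2cc(/C=C/C(=O)c3ccc(Cl)c(Cl)c3)[nH]n2)cc(OC)c1OC` gives -53% in this assay, and compound 3 `COc1ccc(C(=O)/C=C/c2cc(-c3cc(OC)c(OC)c(OC)c3)n[nH]2)cc1` gives -49%. Compound 3 thus stands highest of the three numbers, but its nearest neighbour is close: a number 4 percentage points higher from compound 2 to compound 3 (within the scatter). Its distance to compound 1 is large: a number 48 percentage points higher from compound 1 to compound 3 (beyond the scatter). The related step of a number 44 percentage points higher from compound 1 to compound 2 (beyond the scatter) is large as well.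

Compound 4 `COc1cc(-c2cc(/C=C/C(=O)c3ccc(F)c(F)c3)[nH]n2)cc(OC)c1OC` has not yet been measured in this assay. It differs from compound 3 at one place: 3,4-difluorophenyl in place of 4-methoxyphenyl on a carbonyl carbon. Among the measured compounds shown here, the step that bears most directly on this change is the one between compound 2 and compound 3, since 3,4-dichlorophenyl and 3,4-difluorophenyl differ only in which halogen they carry; that step, a number 4 percentage points higher from compound 2 to compound 3 (within the scatter), was within the scatter. Compound 4 is therefore expected to give about -52% in this assay, within a range from -85% to -20%. The estimate amounts to an expected a number 3 percentage points lower from compound 3 to compound 4 (within the scatter), essentially no step beyond the scatter.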

Compound 4, a percentage reported as activity, at one concentration (the size of the read-out at that concentration, not a potency): -58%
For compound 4 the middle estimate is 6 percentage points above the measured one, within the range that was stated.
By their numbers in this assay, from the lowest: compound 1; then compounds 4, 2 and 3 (each within the scatter of the next).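

In this assay, 3,4-difluorophenyl in place of 4-methoxyphenyl on the carbonyl carbon gives a number 9 percentage points lower from compound 3 to compound 4 (within the scatter), and 3,4-difluorophenyl in place of 3,4-dichlorophenyl gives a number 5 percentage points lower from compound 2 to compound 4 (within the scatter), so this read-out does not separate these three groups at this position. Against 4-aminophenyl the new group gives a number 39 percentage points higher from compound 1 to compound 4 (beyond the scatter), which makes compound 1 the only one of the four that stands apart, now from a third group as well. Nothing available explains why the 4-aminophenyl group stands apart from the others.

On these data alone, whether that standing belongs to the free amine remains open, as a 4-hydroxyphenyl or 4-acetamidophenyl group on the carbonyl carbon would be needed to tell. As far as these compounds go, all four values come from one concentration, so they describe a stronger or weaker effect at that concentration only, and how the compounds compare at other concentrations stays open.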